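The compounds below may be only part of what the source reports. "The series", "measured", "known", "first", "only" and "open" are said of these compounds alone.

Compound 1 `Nc1ccccc1NC(=O)c1ccc(CSC(=S)N2CCN(c3cccnc3)CC2)cc1` is one of three compounds sharing a single core. In a functional assay on MGC-803 cells (Homo sapiens) for antiproliferative activity, read by CCK-8 assay, with a stated time of 72 h, tested at 2 uM (on this read-out higher numbers stand for a stronger effect at the one concentration tested and lower numbers for a weaker effect), compound 1 gives 27.6%. Compound 2 `CC1CCCCN1C(=S)SCc1ccc(C(=O)Nc2ccccc2N)cc1` gives 64.4%, and compound 3 `Nc1ccccc1NC(=O)c1ccc(CSC(=S)N2CCCC2)cc1` gives 27%. Compound 1 therefore stands second highest of the three: its number and that of compound 3 lie within the usual scatter of each other, while the number of compound 2 lies higher by more than the scatter. Going by the values given here, the only measured single-point step, a number 37.4 percentage points lower from compound 2 to compound 3 (beyond the scatter), concerns the group on the thiocarbonyl carbon. Compound 4 `Nc1ccccc1NC(=O)c1ccc(CSC(=S)N2CCN(Cc3ccccc3)CC2)cc1` differs from compound 1 at another place: benzyl in place of pyridin-3-yl on an amine nitrogen in a ring. Among the compounds with values here, no measured step touches that ring nitrogen, and nothing here tells the size of the change; the step expected is a number 6.4 percentage points higher from compound 1 to compound 4 (within the scatter), within the scatter. The value expected for compound 4 is 34%, between 15% and 58%.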

Compound 4, a percentage reported as inhibition, at one concentration (the size of the read-out at that concentration, not a potency): 18.1%
Compound 4: middle estimate off by 15.9 percentage points, on the high side; the range from low to high includes it.
By their numbers in this assay, from the lowest: compounds 4, 3 and 1 (each within the scatter of the next); then compound 2.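

Going by these compounds alone, the first measured change on the amine nitrogen in the six-membered non-aromatic ring, benzyl in place of pyridin-3-yl, gives a number 9.5 percentage points lower from compound 1 to compound 4 (within the scatter) and so stays within the usual scatter. This exchange of one aromatic group for another therefore leaves no readable change at this place, whereas the change on the thiocarbonyl carbon, a number 37.4 percentage points lower from compound 2 to compound 3 (beyond the scatter), goes beyond the scatter. No measured evidence is available to explain this result.

As far as these compounds go, whether a small methyl, an acetyl group or a longer chain ending in a carboxylic acid on this nitrogen would shift the number remains open. So does whether any group here could reach the level of compound 2.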